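Taking One Methyl Group Off Compound 3

This account rests on a few compounds, and the source may have more. Where it says the series, first, only, none or still open, it means among the compounds named here.

Of the compounds shown here, three that share one core have been tested so far in an ADME assay on MT4 cells (Homo sapiens) for cytotoxicity, read by MTT assay (a lower number here means that less compound is tolerated, a higher number that more compound is tolerated), and give very different pictures of tolerance. Compound 1 (`Cc1ccc(NC(=O)CSc2nncnc2-c2ccccc2Cl)c(Br)c1`) reads 45000 nM while compound 2 (`O=C(CSc1nncnc1-c1ccccc1Cl)Nc1ccccn1`) reads 172000 nM and compound 3 (`Cc1ccc(NC(=O)CSc2nncnc2-c2ccccc2Cl)c([N+](=O)[O-])c1`) reads 158000 nM on the same scale. Compound 3 therefore stands level with compound 2, within the usual scatter, and both lie clearly above compound 1.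

Compound 4 (`O=C(CSc1nncnc1-c1ccccc1Cl)Nc1ccccc1[N+](=O)[O-]`) is compound 3 with hydrogen in place of methyl on an aromatic carbon. Going by the values given here, no measured step makes exactly this change, but two come near it. Swapping bromo for nitro gave a 3.5-fold higher number from compound 1 to compound 3 (0.55 log units; beyond the scatter) and replacing 2-bromo-4-methylphenyl with pyridin-2-yl gave a 3.8-fold higher number from compound 1 to compound 2 (0.58 log units; beyond the scatter) as a result. Both steps are modest, and both remove the bromo, which compound 3 no longer carries, so neither size need carry over. Compound 2 also lacks the methyl, and its 172000 nM lies within the scatter of compound 3, although it differs in other ways too. The expected outcome is a 1.1-fold lower number from compound 3 to compound 4 (0.02 log units; within the scatter) and so no step beyond the scatter. For compound 4 the estimated value is 150000 nM with an expected range from 70000 nM to 320000 nM in this measurement.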

Compound 4, half-maximal cytotoxic concentration: 63000 nM
Compound 4: the middle estimate sits 2.4-fold (0.38 log units) above what was measured; the measured number lies below the stated range.
By their numbers in this assay, from the lowest: compounds 1 and 4 (each within the scatter of the next); then compounds 3 and 2 (each within the scatter of the next).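

In this assay the swap of methyl for hydrogen, on a carbon meta to a nitro group and para to a large group, gives a 2.5-fold lower number from compound 3 to compound 4 (0.40 log units; beyond the scatter) and so shows that this single carbon matters to how much compound the cells tolerate when the nitro group is present. The level reading of compound 2 and compound 3 had suggested that the methyl might make no difference, yet the new compound gives a 2.7-fold lower number from compound 2 to compound 4 (0.44 log units; beyond the scatter) and parts clearly from the pyridin-2-yl compound. The 2-nitrophenyl group also gives a 1.4-fold higher number from compound 1 to compound 4 (0.15 log units; within the scatter) and thus cannot be told apart from the 2-bromo-4-methylphenyl group, so the rise seen on going to nitro with the methyl in place, a 3.5-fold higher number from compound 1 to compound 3 (0.55 log units; beyond the scatter), does not appear without it.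

No measurement here accounts for why this methyl counts. Still open, from the compounds shown here alone, is whether the effect depends on the nitro group, which would need a matching pair with bromo in its place, and whether a chlorine, a methoxy group or an ethyl chain on the same carbon would read like the methyl or like the hydrogen.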